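The compounds below may be only part of what the source reports. "The series", "measured", "known", "first", "only" and "open" are said of these compounds alone.

Of the compounds shown here, three built on a shared core have been tested in an assay on a cell-free system (plasma) for antagonist activity at proteinase-activated receptor 4 (Homo sapiens), with a stated time of 5 min, in the presence of a further agent that is not named here (a lower number here means a stronger inhibitor, a higher number a weaker inhibitor), and every result so far has been a limit rather than a number. Compound 1 `COc1ccc2oc(-c3cn4nc(OC)sc4n3)cc2c1` gives > 30000 nM in this assay, which is a limit of the assay. Compound 2 `COc1cc(OCc2ccccc2OC)c2cc(-c3cn4nc(OC)sc4n3)oc2c1` gives > 1000 nM in this assay, again only a limit. Compound 3 `COc1nn2cc(-c3cc4ccc(OCc5ccccc5)cc4o3)nc2s1` carries a benzyloxy group on its core and gives > 30000 nM in this assay, also a limit. So compound 3 stands at the limit of > 30000 nM in this assay, at which 2 of the 3 values shown sit, together with compound 1, while compound 2 stands at the limit of > 1000 nM in this assay, at which 1 of the 3 values shown sits; none of the three gives a measurable number, and no ordering among them can be read from these results.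

Compound 4 `COc1nn2cc(-c3cc4ccccc4o3)nc2s1` is the next compound and has not yet been measured. It differs from compound 3 by a single change, hydrogen in place of benzyloxy on an aromatic carbon. Because compound 3 sits at the limit of > 30000 nM in this assay, at which 2 of the 3 values shown sit, and compound 1 sits there as well, there is no sign that stripping the benzyloxy group will bring compound 4 into a measurable range, so the step is expected to be none beyond the scatter, a step that the limit leaves unreadable from compound 3 to compound 4. The estimated result for compound 4 in this assay is 60000 nM, with a range from 20000 nM to 300000 nM, most likely reported as a limit again.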

Compound 4, half-maximal inhibitory concentration: 15000 nM
For compound 4 the middle estimate is 4.0-fold (0.60 log units) above the measured one; measured number below the stated range.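

In this assay, for the compounds shown here, compound 4, which carries only hydrogen at this carbon of the six-membered aromatic ring, gives 15000 nM, the first actual number in this set rather than a limit. Putting hydrogen in place of benzyloxy gives an at least 2.0-fold lower number from compound 3 to compound 4 (0.30 log units; that floor lies within the scatter), and putting hydrogen in place of methoxy gives an at least 2.0-fold lower number from compound 1 to compound 4 (0.30 log units; that floor lies within the scatter), so neither group is needed to reach a measurable value on the shared core. On these data alone, both steps are only floors that lie within the scatter, and their true size stays unknown because each starts from a limit rather than a number: the limit of > 30000 nM in this assay, at which 2 of the 4 values shown sit.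

As far as these compounds go, whether a small group at this carbon, such as fluorine, a hydroxyl or an amine, would give a lower number than hydrogen remains open, as does whether a shorter chain such as ethoxy would behave like hydrogen or like benzyloxy. Differing from compound 4 in more than one place, compound 2 gives > 1000 nM, which is a limit, so the effect of its two substituents on the core cannot be read from these compounds.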